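Saturating the Allyl Ether of Compound 1

The source may report more compounds than this note shows. Statements on the series, on what has been measured and on what is new or still open speak of the compounds shown alone.

Compound 1 `C=CCOc1ccccc1C1CC(=O)c2ccccc2O1` gives the higher of the two measured numbers in a functional assay on RAW264.7 cells (Mus musculus) for inhibition, read by immunoassay, with a stated time of 12 h, tested at 30 uM (a higher number here means more inhibition at the concentration tested (going by the name of the read-out), a lower number less inhibition), where compound 1 gives 49.3%. Within the data shown here, its only measured neighbour, compound 2 `COCOc1ccccc1C1CC(=O)c2ccccc2O1`, gives 35.2% in this assay, and the one step recorded, a number 14.1 percentage points lower from compound 1 to compound 2 (beyond the scatter), is a methoxy in place of vinyl on a saturated chain carbon bound to an oxygen on an aromatic ring.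

Compound 3 `CCCOc1ccccc1C1CC(=O)c2ccccc2O1` has not yet been measured in this assay. It differs from compound 1 by ethyl in place of vinyl on a saturated chain carbon bound to an oxygen on an aromatic ring. The measured step from compound 1 to compound 2 bears on this only loosely: it replaces the vinyl with an oxygen-bearing group, whereas here the vinyl is simply reduced to ethyl, with the two carbon atoms kept and the double bond outside aromatic rings lost. Among the measured compounds shown here, since the one change recorded at this position lowered the result modestly, a small decrease or no change beyond the scatter is expected for compound 3, as a number 5.3 percentage points lower from compound 1 to compound 3 (within the scatter). Compound 3 is therefore estimated at 44% in this assay, within a range from 28% to 60%.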

Compound 3, a percentage reported as inhibition, at one concentration (the size of the read-out at that concentration, not a potency): 45.7%
For compound 3 the middle estimate is 1.7 percentage points below the measured one; the measured number falls inside the stated range.
By their numbers in this assay, from the lowest: compound 2; then compounds 3 and 1 (each within the scatter of the next).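

The step from vinyl to ethyl (a number 3.6 percentage points lower from compound 1 to compound 3 (within the scatter)) shows that in this assay the double bond outside aromatic rings can be lost at this place without a shift beyond the scatter, something the earlier pair could not show. The step from methoxy to ethyl (a number 10.5 percentage points higher from compound 2 to compound 3 (beyond the scatter)) adds a second comparison at the same place, so compound 2 now lies apart, beyond the scatter, from both compound 1 and compound 3, whose allyloxy and propoxy chains cannot be told apart in this read-out. Among these three compounds, the change that counts is therefore the one to the oxygen-bearing methoxy group rather than the loss of the double bond, and no measurement given here explains why this is so.

The compounds shown leave open how a longer chain such as butoxy, or a chain ending in an amine or a carboxylic acid, would read at this place. Each number is also the size of the read-out at one concentration, so the potency of these compounds remains open.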